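The source may report more compounds than this note shows. Statements on the series, on what has been measured and on what is new or still open speak of the compounds shown alone.

Measured compounds:
- compound 1, `COc1ccc(-c2cc3nc(NC(C)(C)C)[nH]c(=O)c3s2)cc1`: 32300 nM
- compound 2, `COc1ccc(-c2cc3nc(NC(C)C)[nH]c(=O)c3s2)cc1`: 27100 nM
- compound 3, `Cc1ccc(-c2csc3c(=O)[nH]c(NC(C)(C)C)nc23)cc1`: 1400 nM

All three numbers come from an ADME assay on HepG2 cells (Homo sapiens) for cytotoxicity, read by MTT assay, with a stated time of 72 h; on this read-out higher numbers stand for lower toxicity in this test and lower numbers for higher toxicity in this test. Compound 1 and compound 2 share one core and differ only at the amino substituent: hydrogen in place of methyl on a saturated chain carbon bound to a nitrogen on an aromatic ring and two saturated chain carbons. The step is a 1.2-fold lower number from compound 1 to compound 2 (0.08 log units; within the scatter), so on this core the two compounds cannot be told apart in this assay.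

Compound 3 carries a different core; the difference between the two cores is not broken down here. In this assay compound 3 gives the lowest of the three numbers, and its gap to both compound 2 and compound 1 lies beyond the scatter, so compound 3 is the most cytotoxic compound of the set as measured.

Compound 4, `Cc1ccc(-c2csc3c(=O)[nH]c(NC(C)C)nc23)cc1`, has not been measured. It stands to compound 3 as compound 2 stands to compound 1: hydrogen in place of methyl on a saturated chain carbon bound to a nitrogen on an aromatic ring and two saturated chain carbons. The place is described in the same words for both pairs, so this is the same change made on the second core. Within the data shown here, the only precedent, the step from compound 1 to compound 2, was small and within the scatter. On that basis the expected step for compound 4 in this assay is a 1.1-fold lower number from compound 3 to compound 4 (0.03 log units; within the scatter), resting on a 1.2-fold lower number from compound 1 to compound 2 (0.08 log units; within the scatter) and on the value of compound 3, 1400 nM.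

Compound 4 is therefore estimated at 1300 nM in this assay, with the range 500 nM to 3500 nM as the expected spread.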

Compound 4, half-maximal cytotoxic concentration: 8800 nM
The estimate for compound 4 lay 6.8-fold (0.83 log units) below the measured number; the measured number lies above the stated range.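

In this assay, going from tert-butyl to isopropyl on the core of compound 3 gives a 6.3-fold higher number from compound 3 to compound 4 (0.80 log units; beyond the scatter), so on this core the change lowers the cytotoxicity seen in this test. The same change on the core of compound 1 gave a 1.2-fold lower number from compound 1 to compound 2 (0.08 log units; within the scatter), and the two steps do not agree, so the step measured on one core is not a safe guide to the step on the other in this read-out: the same change on two cores in this assay, a 1.2-fold lower number (0.08 log units; within the scatter) from compound 1 to compound 2 and a 6.3-fold higher number (0.80 log units; beyond the scatter) from compound 3 to compound 4, 7.5-fold (0.87 log units) apart, beyond the scatter of two such steps

Among these compounds, this rests on only two matched pairs, so it shows that the outcome of this change depends on the core, but not which part of the core is responsible, nor why the steps part ways.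

Still open, from the compounds shown here alone, is whether the sensitivity to the amino substituent on the core of compound 3 extends beyond tert-butyl and isopropyl, for example to ethyl, cyclopropyl or a longer chain such as n-butyl in the same place. Among the compounds shown here, the same groups on the core of compound 1 would show whether that core stays as flat as its single pair suggests, or whether that pair merely happens to show no separation.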